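A few compounds are considered here, and "the series" means these few. Any claim that something is new, unique, unknown or untested is made for them only; others in the source may bear on it.

Of the compounds shown here, three built on one shared core have been measured in an assay for inhibition of Indoleamine 2,3-dioxygenase 1 (Homo sapiens), with a stated time of 1 h, tested at 10 uM; on this read-out lower numbers stand for less inhibition and higher numbers for more inhibition at the one concentration tested (going by the name of the read-out). Compound 1, `Nc1cccc(CNc2cc(Br)cc3[nH]ncc23)c1`, gives 31%. Compound 2, `Nc1cc(CNc2cc(Br)cc3[nH]ncc23)ccc1O`, gives 32%. Compound 3, `Oc1ccc(CNc2cc(Br)cc3[nH]ncc23)c(F)c1`, gives 69%. Among these three numbers compound 2 stands second highest; its nearest neighbour is compound 1, within the scatter, and the furthest is compound 3, beyond the scatter. Within the data shown here, the only one-place step among them, a number 1 percentage points higher from compound 1 to compound 2 (within the scatter), came with hydroxy in place of hydrogen on an aromatic carbon.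

Compound 4, `Cc1cc(CNc2cc(Br)cc3[nH]ncc23)ccc1O`, has not yet been measured. It differs from compound 2 in one place: methyl in place of amino on an aromatic carbon. Among the measured compounds shown here, no measured step swaps amino for methyl, so nothing bears on it directly, and the step from compound 1 to compound 2 concerns a different change. Compound 3 keeps the hydroxy and lacks the amino but differs in more than one place, so only the two values can be set side by side: compound 2 gives 32% while compound 3 gives 69%. For compound 4 a step of a number 13 percentage points higher from compound 2 to compound 4 (beyond the scatter) in this assay is expected, a possible modest rise carrying wide uncertainty. Compound 4 is therefore estimated at 45%, with a range from 25% to 70%.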

Compound 4, a percentage reported as inhibition, at one concentration (the size of the read-out at that concentration, not a potency): 28%
Compound 4: the middle estimate sits 17 percentage points above what was measured, within the range that was stated.
By their numbers in this assay, from the lowest: compounds 4, 1 and 2 (each within the scatter of the next); then compound 3.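

In this assay, methyl in place of amino on an aromatic carbon, ortho to a hydroxy group, gives a number 4 percentage points lower from compound 2 to compound 4 (within the scatter). Among these compounds, this is the first look at this position, and the read-out does not separate the two groups here, even though amino counts as a hydrogen-bond donor and acceptor while methyl counts as neither. No evidence is available that speaks to the reason for this result.

On these data alone, two groups at one position are a thin sample, so it remains open whether a carboxylic acid, a methoxy group or a longer chain such as propyl would read the same at this position. As far as these compounds go, it also remains open whether amino and methyl would still read alike on a ring without the neighbouring hydroxy group.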